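This account rests on a few compounds, and the source may have more. Where it says the series, first, only, none or still open, it means among the compounds named here.

Measured in an ADME assay on HEK293 cells (Homo sapiens) for cytotoxicity, with a stated time of 72 h; a higher number here means that more compound is needed for the effect, a lower number that less compound is needed:
- compound 1 `C=C[C@](C)(CCCC(C)C)CCc1ccc(O)cc1`: > 36600 nM
- compound 2 `C=C[C@@](C)(/C=C/c1ccc(O)c(CO)c1)CCC=C(C)C`: > 36600 nM
- compound 3 `C=C[C@@](C)(/C=C/c1ccc(O)c(/C=C/C(=O)c2ccccc2)c1)CCC=C(C)C`: > 7410 nM

All three values are limits and not numbers. Compound 3 gives > 7410 nM, which is a limit. The other two compounds stand at a separate limit, (the limit of > 36600 nM in this assay, at which 2 of the 3 values shown sit).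

Compound 4 `C=C[C@@](C)(/C=C/c1ccc(O)c(/C=C/C(=O)OCC)c1)CCC=C(C)C` has ethoxy in place of phenyl on a carbonyl carbon, so benzoyl becomes ethoxycarbonyl: ethoxy in place of phenyl on a carbonyl carbon.

Among the compounds with values here, no measured step shows what such a change does. No step beyond the usual scatter is therefore expected in this assay, and the estimated change is a step that the limit leaves unreadable from compound 3 to compound 4. For compound 4 the expected value is 12000 nM, with an estimated range of 5000 nM to 37000 nM.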

Compound 4, half-maximal effective concentration: > 36600 nM
Compound 4 gave a limit, no number; the forecaster's own chance of this, stated with the estimate: 80%; middle value at least 3.0-fold (0.48 log units) from the limit.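

In this assay compound 4 gives > 36600 nM, a limit and not a number. Within the data shown here, no step to compound 4 can be read from compound 2 or compound 3, whose values are also limits. The compounds shown leave open at what concentration any of them reaches the half-maximal effect.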